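The source may hold more compounds than are shown below. What is called first, only, known or untested is meant among the compounds shown, and "the series" means these compounds.

Measured so far:
compound 1, `CC(C)[C@H](NC(=O)COc1cccc2ccccc12)C(=O)N[C@@H](CC(=O)O)C(=O)COc1cc(C(F)(F)F)n(C)n1` — 46000 nM
compound 2, `CC(C)[C@H](NC(=O)COc1cccc2ccccc12)C(=O)N[C@@H](CC(=O)O)C(=O)COc1ccnc(C(F)(F)F)n1` — 37000 nM

Both compounds share a core and differ only in the group on an oxygen on a saturated carbon. In a functional assay on Jurkat cells (Homo sapiens) for inhibition (on this read-out higher numbers stand for weaker inhibition and lower numbers for stronger inhibition), compound 1 gives 46000 nM and compound 2 gives 37000 nM; the step of a 1.2-fold lower number from compound 1 to compound 2 (0.09 log units; within the scatter) is within the scatter, so the two numbers are not distinguishable. Compound 2 stands with the lower of the two numbers, but only by a margin that the scatter covers.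

Compound 3, `CC(C)[C@H](NC(=O)COc1cccc2ccccc12)C(=O)N[C@@H](CC(=O)O)C(=O)COc1[nH]cnc2nncc1-2`, is not yet measured. It differs from compound 2 by a group of 9 heavy atoms (5 carbon, 4 nitrogen; one five-membered aromatic ring with 2 hetero atoms, one six-membered aromatic ring with 2 hetero atoms) in place of a group of 10 heavy atoms (5 carbon, 2 nitrogen, 3 fluorine; one six-membered aromatic ring with 2 hetero atoms), on an oxygen on a saturated carbon. Among the compounds with values here, no measured step bears directly on this change: the only step available, a 1.2-fold lower number from compound 1 to compound 2 (0.09 log units; within the scatter), exchanges one heteroaryl group for another at the same place and stays within the scatter. Within the data shown here, on that basis no step beyond the scatter is expected in this assay for compound 3, in either direction, though the entering group has no precedent and the range is set wide. Compound 3 is therefore estimated at 30000 nM, between 8000 nM and 120000 nM, which corresponds to an expected step of a 1.2-fold lower number from compound 2 to compound 3 (0.09 log units; within the scatter).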

Compound 3, half-maximal inhibitory concentration: 161000 nM
Estimate against measurement, compound 3: 5.4-fold (0.73 log units) below, outside the stated range (above it).
By their numbers in this assay, from the lowest: compounds 2 and 1 (each within the scatter of the next); then compound 3.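

Notes on the group on an oxygen on a saturated carbon: in this assay this place is not indifferent to the group it carries, as the exchange here now gives a 4.4-fold higher number from compound 2 to compound 3 (0.64 log units; beyond the scatter) and a 3.5-fold higher number from compound 1 to compound 3 (0.54 log units; beyond the scatter), the first steps in the series beyond the scatter. Both steps are modest and point the same way, and both start from a group with a single aromatic ring bearing trifluoromethyl, while the group in compound 3 has a five-membered and a six-membered aromatic ring and no fluorine; against the group of compound 2 it also moves from 0 to 1 hydrogen-bond donor, so several features change together and the steps cannot be assigned to any one of them. Nothing at hand accounts for the higher number of compound 3.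

Open, on these data alone, is whether a plain phenyl group on the same oxygen would stay with compound 1 and compound 2 or move towards compound 3. Also open, as far as these compounds go, is whether a methyl group in place of the ring hydrogen-bond donor of compound 3 would change its number.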